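The compounds below may be only part of what the source reports. "The series", "measured", "known", "first", "only" and "open" are said of these compounds alone.

Measured compounds:
Compound 1 `Nc1nc(O)nc2c1nc(O)n2Cc1ccccc1`: 1 mg/kg
Compound 2 `CCSc1nc(N)c2nc(O)n(Cc3ccccc3)c2n1`: 0.1 mg/kg
Compound 3 `CCCCSc1nc(N)c2nc(O)n(Cc3ccccc3)c2n1`: 0.3 mg/kg

In a functional assay on the whole organism for activation, with Mus musculus as the target (on this read-out higher numbers stand for an effect only at larger amounts of compound and lower numbers for an effect already at smaller amounts), compound 3 gives 0.3 mg/kg, the second highest of the three numbers; compound 2 gives 0.1 mg/kg and compound 1 gives 1 mg/kg. Compound 4 `CCCCCOc1nc(N)c2nc(O)n(Cc3ccccc3)c2n1` differs from compound 3 by pentyloxy in place of butylsulfanyl on an aromatic carbon. Among the compounds with values here, three measured steps bear on this change. Replacing hydroxy by an alkylsulfanyl group gave a 10-fold lower number from compound 1 to compound 2 (1.00 log units; beyond the scatter) and a 3.3-fold lower number from compound 1 to compound 3 (0.52 log units; beyond the scatter), while lengthening the chain gave a 3.0-fold higher number from compound 2 to compound 3 (0.48 log units; beyond the scatter). No measured step exchanges sulfur for oxygen, so that part of the change has no precedent among these compounds; the longer chain in compound 4, by analogy with a 3.0-fold higher number from compound 2 to compound 3 (0.48 log units; beyond the scatter), points toward a somewhat higher number. Compound 4 is therefore expected to show a 1.7-fold higher number from compound 3 to compound 4 (0.22 log units; within the scatter), giving an estimated 0.5 mg/kg in this assay, with a range from 0.1 mg/kg to 3 mg/kg.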

Compound 4, minimum effective dose: 0.3 mg/kg
Compound 4: middle estimate off by 1.7-fold (0.22 log units), on the high side; measured number inside the range.
By their numbers in this assay, from the lowest: compound 2; then compounds 3 and 4 (each within the scatter of the next); then compound 1.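

In this assay, pentyloxy for butylsulfanyl gives no change at the digits printed from compound 3 to compound 4 (within the scatter) at this aromatic carbon between two ring nitrogen atoms, so at these chain lengths an oxygen-linked chain reads like a sulfur-linked one, although the linking atom and the chain length change together. Pentyloxy also gives a 3.3-fold lower number from compound 1 to compound 4 (0.52 log units; beyond the scatter) against hydroxy, and a 3.0-fold higher number from compound 2 to compound 4 (0.48 log units; beyond the scatter) against ethylsulfanyl, showing that an alkyl chain on oxygen is tolerated here. No supporting data bear on this result.

The compounds shown leave open how ethoxy or butoxy would read, which would separate the linking atom from the chain length. As far as these compounds go, an amine at this position also remains open.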